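From Fluoro to Nitro on the Aromatic Ring

The source may report more compounds than this note shows. Statements on the series, on what has been measured and on what is new or still open speak of the compounds shown alone.

In a functional assay on Bel-7402 cells (Homo sapiens) for cytotoxicity, read by MTT assay, with a stated time of 72 h (on this read-out lower numbers stand for stronger inhibition and higher numbers for weaker inhibition), compound 1 `CC(=C\c1ccccc1)/C=C1\CCC=CC1=O` gives 3900 nM. Compound 2 `O=C1C=CCC/C1=C\C(Br)=C\c1ccccc1` gives > 10000 nM, which is a limit of the assay and not a number. Going by the values given here, compound 3 `O=C1C=CCC/C1=C\C=C\c1ccc(F)cc1` gives 1800 nM, the lowest number measured so far and lower than the value of compound 1 by more than the scatter.

Compound 4 `O=C1C=CCC/C1=C\C=C\c1ccc([N+](=O)[O-])cc1` has not yet been measured. Its difference from compound 3 is nitro in place of fluoro on an aromatic carbon, para to a large group. Among the compounds with values here, only one measured step is available, an at least 2.5-fold higher number from compound 1 to compound 2 (0.40 log units; beyond the scatter), with bromo in place of methyl on a chain carbon. It shows that a single change can shift the result in this assay, but it lies on the chain, so it gives no direction for a change on the aromatic ring. The value of compound 3 at 1800 nM therefore remains the anchor. The expected result is a 1.1-fold higher number from compound 3 to compound 4 (0.05 log units; within the scatter), so no shift beyond the scatter is expected, although the uncertainty is wide. For compound 4, the estimated value is 2000 nM, with an expected range from 600 nM to 7000 nM.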

Compound 4, half-maximal inhibitory concentration: 4200 nM
Beside the measured number, compound 4's estimate is 2.1-fold (0.32 log units) below it; the range from low to high includes it.
By their numbers in this assay, from the lowest: compound 3; then compounds 1 and 4 (each within the scatter of the next). At a limit, above all of these: compound 2.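

In this assay, going by these compounds alone, the only earlier step lay on the chain, so it left open whether the aromatic ring responds to a change at all. Nitro in place of fluoro on an aromatic carbon, para to a large group, gives a 2.3-fold higher number from compound 3 to compound 4 (0.37 log units; beyond the scatter) and so answers that question: a single exchange at this ring carbon also moves the result beyond the scatter. Of these two groups, fluoro goes with the stronger inhibition, but two groups at one place make no trend.

As far as these compounds go, whether an amine, a methoxy group or chlorine at this ring carbon would give a number closer to that of compound 3 or of compound 4 remains open. The data shown offer no measurement that accounts for this shift.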